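One Methyl Removed: What to Expect for Compound 4

The compounds below may be only part of what the source reports. "The series", "measured", "known", "first", "only" and "open" are said of these compounds alone.

Measured compounds:
Compound 1, `COc1cc(-c2nn(-c3cccc(NC(=O)Nc4cc(C(F)(F)F)cc(C(F)(F)F)c4)c3)cc2-c2ccncc2)ccc1Cl`, gives 1280 nM in a functional assay on UO-31 cells (Homo sapiens) for inhibition, read by sulforhodamine B assay, with a stated time of 48 h; on this read-out lower numbers stand for stronger inhibition of growth and higher numbers for weaker inhibition of growth.
Compound 2, `O=C(Nc1cccc(-n2cc(-c3ccncc3)c(-c3ccc(Cl)c(O)c3)n2)c1)Nc1cc(C(F)(F)F)cc(C(F)(F)F)c1`, gives 1900 nM in this assay.
Compound 3, `COc1cc(-c2nn(-c3cccc(NC(=O)Nc4ccc(Cl)c(C(F)(F)F)c4)c3)cc2-c2ccncc2)ccc1Cl`, gives 4100 nM in this assay.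

Compound 4, `O=C(Nc1cccc(-n2cc(-c3ccncc3)c(-c3ccc(Cl)c(O)c3)n2)c1)Nc1ccc(Cl)c(C(F)(F)F)c1`, has not yet been measured in this assay. It differs from compound 3 in one place: hydrogen in place of methyl on an oxygen on an aromatic ring. The same change has already been made once, from compound 1 to compound 2, where it is described as hydrogen in place of methyl on an oxygen on an aromatic ring and gave a 1.5-fold higher number from compound 1 to compound 2 (0.17 log units; within the scatter). How the core of compound 1 differs from the core of compound 3 is not broken down here; compound 3 simply gives the highest of the three numbers. Among the compounds with values here, the earlier step, a 1.5-fold higher number from compound 1 to compound 2 (0.17 log units; within the scatter), is the only guide available. A step of similar size is therefore expected, a 1.5-fold higher number from compound 3 to compound 4 (0.17 log units; within the scatter). Compound 4 is estimated at 6000 nM, with a likely range from 3000 nM to 12000 nM.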

Compound 4, concentration for total growth inhibition: 3010 nM
Beside the measured number, compound 4's estimate is 2.0-fold (0.30 log units) above it; low and high end bracket the measured number.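

In this assay, replacing methoxy with hydroxy gave a 1.4-fold lower number from compound 3 to compound 4 (0.13 log units; within the scatter), so on this second core the change again produces no step beyond the usual scatter of repeated measurements. Set side by side, the two results do not differ by more than such measurements allow: the same change on two cores in this assay, a 1.5-fold higher number (0.17 log units; within the scatter) from compound 1 to compound 2 and a 1.4-fold lower number (0.13 log units; within the scatter) from compound 3 to compound 4, 2.0-fold (0.31 log units) apart, within the scatter of two such steps. Within the data shown here, this shows that the swap carried over between these two cores with little visible consequence, but it does not show that the same would hold on any other core, and with only two pairs a small real effect could stay hidden in the scatter.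

The compounds shown leave open what other groups in this place would do, such as an amine, a carboxylic acid or a longer chain like ethoxy.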